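This account rests on a few compounds, and the source may have more. Where it says the series, first, only, none or still open, it means among the compounds named here.

Measured set:
Compound 1 `CC(C(=O)NCc1ccc(C(F)(F)F)cc1N1CCCCCC1)c1ccc(NS(C)(=O)=O)c(F)c1`: in an assay on CHO cells for antagonist activity at transient receptor potential cation channel subfamily V member 1 (Homo sapiens), read by FLIPR (a lower number here means a stronger inhibitor, a higher number a weaker inhibitor), compound 1 gives 1.6 nM.
Compound 2 `CC(C(=O)NCc1ccc(C(F)(F)F)cc1N1CCC(C)(C)CC1)c1ccc(NS(C)(=O)=O)c(F)c1`: in this assay compound 2 gives 1.3 nM.
Compound 3 `CC(C(=O)NCc1ccc(C(F)(F)F)cc1OC1CCCC1)c1ccc(NS(C)(=O)=O)c(F)c1`: in this assay compound 3 gives 0.6 nM.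

Compound 3 holds the lowest number of the three. The steps of a 2.7-fold lower number from compound 1 to compound 3 (0.43 log units; beyond the scatter) and a 2.2-fold lower number from compound 2 to compound 3 (0.34 log units; beyond the scatter) are both modest yet beyond the scatter, whereas a 1.2-fold lower number from compound 1 to compound 2 (0.09 log units; within the scatter) stays within it. Compound 4 `CC(C(=O)NCc1ccc(C(F)(F)F)cc1OCc1ccccc1)c1ccc(NS(C)(=O)=O)c(F)c1` differs from compound 3 in one place: benzyl in place of cyclopentyl on an oxygen on an aromatic ring. For the measured compounds named here, no measured step exchanges groups on that oxygen; the three measured steps all swap the entire group attached to the aromatic carbon, and even the largest of them, a 2.7-fold lower number from compound 1 to compound 3 (0.43 log units; beyond the scatter), is modest. On that basis a step of no more than modest size is expected for a 1.7-fold higher number from compound 3 to compound 4 (0.22 log units; within the scatter), with the direction uncertain and a result within the scatter of compound 3 seen as most likely. Compound 4 is therefore estimated at 1 nM, with a range from 0.3 nM to 3 nM.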

Compound 4, inhibition constant: 0.9 nM
For compound 4 the middle estimate is 1.1-fold (0.05 log units) above the measured one, within the range that was stated.
By their numbers in this assay, from the lowest: compounds 3, 4, 2 and 1 (each within the scatter of the next, the first and the last beyond it).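

In this assay the oxygen on the aromatic ring accepts benzyl in place of cyclopentyl with a 1.5-fold higher number from compound 3 to compound 4 (0.18 log units; within the scatter), so an aromatic ring and a non-aromatic carbon ring on this oxygen are not told apart here. Benzyloxy also fails to separate from the two ring amines, with a 1.4-fold lower number from compound 2 to compound 4 (0.16 log units; within the scatter) and a 1.8-fold lower number from compound 1 to compound 4 (0.25 log units; within the scatter), so the separation printed for cyclopentyloxy against those groups does not carry over to benzyloxy. No available measurement explains why these values stay so close.

On these data alone, whether a carboxylic acid, an amine or a longer chain such as n-hexyl on this oxygen would keep the number in this range stays open. So does whether a fluorine or a methoxy group on the benzyl ring would separate from plain benzyl.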